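A few compounds are considered here, and "the series" means these few. Any claim that something is new, unique, unknown or untested is made for them only; others in the source may bear on it.

Measured compounds:
- compound 1, `COc1ccc(-c2cc3ccccc3c(-c3cccc(O)c3)n2)cc1` — 5360 nM in a functional assay on DU-145 cells (Homo sapiens) for cytotoxicity, read by CCK-8 assay and cell counting, with a stated time of 72 h; on this read-out higher numbers stand for weaker inhibition and lower numbers for stronger inhibition
- compound 2, `COc1cc(OC)cc(-c2cc3ccccc3c(-c3cccc(OC)c3)n2)c1` — > 50000 nM in this assay

Compound 2 stands at the weak end of the two values shown. Its result in this assay is a limit, (the limit of > 50000 nM in this assay, at which 1 of the 2 values shown sits), so no number is known for it. Compound 1 carries a hydroxyl on one pendant ring and gives 5360 nM; compound 2 carries a methoxy on every pendant ring. Of this pair one can say only what the two values show, since they differ in more than one place.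

Compound 3, `COc1cc(OC)cc(-c2cc3ccccc3c(-c3ccc(O)cc3)n2)c1`, is not yet measured. It differs from compound 2 in one place: 4-hydroxyphenyl in place of 3-methoxyphenyl on an aromatic carbon. The change brings a free hydroxyl back onto a pendant ring, as in compound 1.

Compound 3 is expected to give a measurable number rather than a limit, with a step of an at least 4.1-fold lower number from compound 2 to compound 3 (0.61 log units; beyond the scatter) toward stronger inhibition. This rests on compound 1, which with a hydroxyl on a pendant ring gives 5360 nM. The estimate for compound 3 in this assay is 12000 nM, within 3000 nM to 50000 nM.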

Compound 3, half-maximal inhibitory concentration: 4580 nM
Beside the measured number, compound 3's estimate is 2.6-fold (0.42 log units) above it; low and high end bracket the measured number.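

In this assay, the change from 3-methoxyphenyl to 4-hydroxyphenyl is the first comparison among these compounds that can be read in one place, and it gives an at least 10-fold lower number from compound 2 to compound 3 (1.03 log units; beyond the scatter). With the rest of the structure the same, the group on this aromatic carbon next to the ring nitrogen therefore separates a measurable result from one with no number, so this position is not indifferent to what it carries. The result for compound 2 is a limit, and the step built on it therefore gives only a bound on the size of the change: the limit of > 50000 nM in this assay, at which 1 of the 3 values shown sits.

The swap alters two things at once, since the 4-hydroxyphenyl carries 1 hydrogen-bond donor where the 3-methoxyphenyl has 0, and the oxygen also stands at a different place on the pendant ring, so the compounds shown do not tell whether the free hydroxyl or its location accounts for the step. They also leave open whether an amine or a carboxylic acid on that pendant ring would go with a measurable number, and how far a longer chain on the oxygen would be tolerated at this position.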